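The source may hold more compounds than are shown below. What is called first, only, known or untested is meant among the compounds shown, and "the series" means these compounds.

Working notes on the series built on the core of compound 1 `CCCCCCCCCCCC[C@@H](O)[C@H]1CC[C@H]([C@H](O)CCCCCCCCCCNC(=O)c2ccco2)O1`. In a functional assay on HBC4 cells (Homo sapiens) for inhibition, read by colorimetric assay and sulforhodamine B assay, with a stated time of 48 h (a lower number here means a stronger inhibitor of growth, a higher number a weaker inhibitor of growth), compound 1 gives 100000 nM. Compound 2 `CCCCCCCCCCCC[C@@H](O)[C@H]1CC[C@H]([C@H](O)CCCCCCCCCCNC(=O)c2ccoc2)O1` gives 100000 nM. Compound 3 `CCCCCCCCCCCC[C@@H](O)[C@H]1CC[C@H]([C@H](O)CCCCCCCCCCNC(=O)c2cncs2)O1` gives 100000 nM, which places it level with the other two at the digits available.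

Compound 4 `CCCCCCCCCCCC[C@@H](O)[C@H]1CC[C@H]([C@H](O)CCCCCCCCCCNC(=O)c2ccsc2)O1` has thiophen-3-yl in place of 1,3-thiazol-5-yl on a carbonyl carbon. Three measured steps exchange the five-membered aromatic ring at this same place: no change at the digits printed from compound 1 to compound 2 (within the scatter), no change at the digits printed from compound 1 to compound 3 (within the scatter) and no change at the digits printed from compound 2 to compound 3 (within the scatter). None of them goes beyond the scatter, so no step beyond the scatter is expected in this assay, in either direction. Within the data shown here, only three compounds support this expectation, and none of them carries a thiophene ring, so some allowance for a stronger result remains. The expected step is no change at the digits printed from compound 3 to compound 4 (within the scatter). For compound 4 the estimated value is 100000 nM, with an expected range from 40000 nM to 100000 nM.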

Compound 4, concentration for 50% growth inhibition: 100000 nM
The estimate for compound 4 equals the measured number at the digits printed, and the stated range covers the measured number.
By their numbers in this assay, from the lowest: compounds 1, 2, 3 and 4 (each within the scatter of the next).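

In this assay the thiophene ring reads the same as each ring already tested at this place on the carbonyl carbon (no change at the digits printed from compound 3 to compound 4 (within the scatter); no change at the digits printed from compound 2 to compound 4 (within the scatter); no change at the digits printed from compound 1 to compound 4 (within the scatter)). The range of rings at this place now includes thiophen-3-yl, and going from 1,3-thiazol-5-yl to it, from 2 hetero atoms to 1 hetero atom and from 2 hydrogen-bond acceptors to 1 hydrogen-bond acceptor, moves nothing beyond the scatter. Among these compounds, all four compounds stand level, so no step at this position yet separates any two of them. No supporting measurement bears on this reading.

Still open, going by these compounds, is whether a phenyl or pyridine ring, or a ring carrying an amine or a carboxylic acid, would move the number. A shorter chain on the shared core is equally untested here.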